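Working notes: solubility across three sulfur-linked analogues

The source may report more compounds than this note shows. Statements on the series, on what has been measured and on what is new or still open speak of the compounds shown alone.

Compound 1 `COC(=O)Nc1nc2cc(Sc3ccccc3)ccc2n1COP(=O)(O)O` and compound 2 `COC(=O)Nc1nc2cc([S+]([O-])c3ccccc3)ccc2n1COP(=O)(O)O` share one core and differ only at the sulfur-bearing substituent. In a physicochemical assay for solubility, at pH 7.4 (a higher number here means a more soluble compound, a lower number a less soluble compound), compound 1 gives 130000000 nM. In this assay compound 2 gives > 50000000 nM, which is a limit of the assay and not a number. Going by the values given here, the single measured step, a step that the limit leaves unreadable from compound 1 to compound 2, therefore has no readable size, and the limit of > 50000000 nM in this assay, at which 1 of the 2 values shown sits, marks where compound 2 sits. Compound 3 `CCCSc1ccc2c(c1)nc(NC(=O)OC)n2COP(=O)(O)O` differs from compound 2 by a group of 4 heavy atoms (3 carbon, 1 sulfur; no ring) in place of a group of 8 heavy atoms (6 carbon, 1 oxygen, 1 sulfur; one six-membered aromatic ring of carbon only), on an aromatic carbon. Among the compounds with values here, no measured step bears directly on this change, and the only step in the set is unreadable, so no direction beyond the scatter can be drawn for it. Compound 3 is expected to remain near the top of the range seen so far, an estimated step that the limit leaves unreadable from compound 2 to compound 3. The estimate for compound 3 is 100000000 nM, between 30000000 nM and 300000000 nM.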

Compound 3, solubility: > 50000000 nM
Compound 3 ended at the assay's limit; the forecaster's own chance of this, stated with the estimate: 50%; the middle value lies beyond the limit too.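

In this assay, going by these compounds alone, compound 3 gives > 50000000 nM, a limit of the assay and not a number, so no new step among compound 1, compound 2 and compound 3 can be read. The compounds shown leave open whether propyl and phenyl on the sulfur differ in solubility at all.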